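Hydrogen in place of nitro on compound 2

The source may hold more compounds than are shown below. What is called first, only, known or untested is meant among the compounds shown, and "the series" means these compounds.

compound 1 `COc1ccc([C@@H]2C/C(=N/OCc3cn(-c4ccc(Cl)cc4C)nn3)c3cc(CC=C(C)C)c(OC)cc3O2)cc1` gives 37%
compound 2 `COc1cc2c(cc1CC=C(C)C)C(=O)C[C@@H](c1ccc(Oc3cccc([N+](=O)[O-])c3)cc1)O2` gives 53%
compound 3 `COc1cc2c(cc1CC=C(C)C)[C@H](O)C[C@@H](c1ccc(O)cc1)O2` gives 49%

All three values come from a functional assay on MCF7 cells (Homo sapiens) for inhibition, read by sulforhodamine B assay, with a stated time of 48 h, tested at 50 uM (on this read-out lower numbers stand for less inhibition of growth and higher numbers for more inhibition of growth at the one concentration tested), and make up the whole measured set. Compound 2 (53%) and compound 3 (49%) lie within the scatter of each other, while compound 1 (37%) lies lower than compound 2 by more than the scatter.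

Compound 4 `COc1cc2c(cc1CC=C(C)C)C(=O)C[C@@H](c1ccc(Oc3ccccc3)cc1)O2` differs from compound 2 in one place (hydrogen in place of nitro on an aromatic carbon), with hydrogen in place of nitro on an aromatic carbon, 3-nitrophenoxy to phenoxy. Among the compounds with values here, no two measured compounds differ in one place only, so the data hold no direct measure of this change. The measured compounds differ in several places yet span only from compound 1 (37%) to compound 2 (53%), so no step beyond the scatter is expected in this assay for this single change. The expected change is a number 5 percentage points lower from compound 2 to compound 4 (within the scatter) and this estimated step is small and slightly downward. For compound 4 the estimated value is 48% with an expected range from 33% to 62% in this read-out.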

Compound 4, percent growth inhibition at one concentration: 69%
Compound 4: the middle estimate sits 21 percentage points below what was measured; measured number above the stated range.
By their numbers in this assay, from the lowest: compound 1; then compounds 3 and 2 (each within the scatter of the next); then compound 4.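

In this assay, within the data shown here, hydrogen in place of nitro on the aromatic carbon gives a number 16 percentage points higher from compound 2 to compound 4 (beyond the scatter), the only comparison that isolates a single change. The position therefore affects the read-out, and in this pair the nitro is not required for growth inhibition at the one concentration tested: the plain phenoxy group of compound 4 gives the higher number, not the 3-nitrophenoxy group of compound 2. No measurement shown accounts for this step.

A single pair cannot show whether only nitro lowers the number or whether other groups on the same carbon do so too, and an amine, a methoxy or a carboxylic acid there would separate these readings. From the compounds shown here alone, whether the step persists at other concentrations also remains open.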